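The compounds below may be only part of what the source reports. "The series", "measured", "known", "first", "only" and "open" are said of these compounds alone.

Measured so far in an ADME assay on MT4 cells (Homo sapiens) for cytotoxicity, read by MTT assay; a higher number here means that more compound is tolerated, a lower number that less compound is tolerated:

compound 1 `COc1ccc(-c2c(C)nc(NC(=O)NC3CCCCC3)c(C)c2C(OC(C)(C)C)C(=O)O)cc1`: 19000 nM
compound 2 `Cc1nc(NC(=O)NC2CCCCC2)c(C)c(C(OC(C)(C)C)C(=O)O)c1-c1ccc(Cl)cc1`: 16000 nM
compound 3 `Cc1ccc(-c2c(C)nc(Nc3nc4ccccc4n3C)c(C)c2C(OC(C)(C)C)C(=O)O)cc1C`: 14000 nM

The three numbers sit close together. Compound 3 stands within the scatter of both others, nearer to compound 2 than to compound 1, so no order among them can be read. For the measured compounds named here, the only step between measured compounds that differ in one place, a 1.2-fold lower number from compound 1 to compound 2 (0.07 log units; within the scatter), changes a group on an aromatic carbon and is itself within the scatter.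

Compound 4 `Cc1ccc(-c2c(C)nc(Nc3nc4ccccc4s3)c(C)c2C(OC(C)(C)C)C(=O)O)cc1C` differs from compound 3 by 1,3-benzothiazol-2-yl in place of 1-methyl-1H-benzimidazol-2-yl on a nitrogen on an aromatic ring. Going by the values given here, no measured step touches this part of the molecule; the expectation therefore rests only on the flatness of this assay across the series. No change beyond the scatter is expected, no change at the digits printed from compound 3 to compound 4 (within the scatter). Compound 4 is estimated at 14000 nM, with a range from 7000 nM to 28000 nM.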

Compound 4, half-maximal cytotoxic concentration: 6600 nM
Beside the measured number, compound 4's estimate is 2.1-fold (0.33 log units) above it; the measured number lies below the stated range.
By their numbers in this assay, from the lowest: compound 4; then compounds 3, 2 and 1 (each within the scatter of the next).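

For the compounds shown here, the step of a 2.1-fold lower number from compound 3 to compound 4 (0.33 log units; beyond the scatter) in this assay is the first single change to go beyond the scatter, and it sits on the nitrogen on an aromatic ring, away from the group changed in the earlier step. The two groups have the same ring types and the same counts of hydrogen-bond donors and acceptors, so those counts do not separate them. Nothing measured here accounts for the shift.

The compounds shown leave open whether the lower number follows the sulfur or the absence of the methyl on nitrogen. An unmethylated 1H-benzimidazol-2-yl or a 1,3-benzoxazol-2-yl at this place would help separate the two.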